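From 2,3-dihydroxyphenyl to 4-hydroxyphenyl: what to expect

This account rests on a few compounds, and the source may have more. Where it says the series, first, only, none or still open, it means among the compounds named here.

Of the compounds shown here, three with a shared core have been tested in a functional assay on P388 cells (Mus musculus) for cytotoxicity; on this read-out higher numbers stand for weaker inhibition and lower numbers for stronger inhibition: compound 1 `Cc1cc(-c2c(F)cc3c(=O)c(Cc4c(O)cccc4O)cn(C4CC4)c3c2F)cc(C)n1` gives 250 nM, compound 2 `Cc1cc(-c2c(F)cc3c(=O)c(Cc4ccc(Cl)cc4)cn(C4CC4)c3c2F)cc(C)n1` gives 20000 nM, and compound 3 `Cc1cc(-c2c(F)cc3c(=O)c(Cc4cccc(O)c4O)cn(C4CC4)c3c2F)cc(C)n1` gives 880 nM. Compound 3 therefore holds the second highest of the three numbers, much nearer compound 1 than compound 2.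

The next compound, compound 4 `Cc1cc(-c2c(F)cc3c(=O)c(Cc4ccc(O)cc4)cn(C4CC4)c3c2F)cc(C)n1`, differs from compound 3 by 4-hydroxyphenyl in place of 2,3-dihydroxyphenyl on a saturated chain carbon bound to an aromatic carbon: 4-hydroxyphenyl replaces 2,3-dihydroxyphenyl on a saturated chain carbon bound to an aromatic carbon.

For the measured compounds named here, three measured steps bear on this. Exchanging one dihydroxyphenyl for another gave a modest change, a 3.5-fold higher number from compound 1 to compound 3 (0.55 log units; beyond the scatter). Moving to 4-chlorophenyl, which has no hydroxy group, gave large changes, an 80-fold higher number from compound 1 to compound 2 (1.90 log units; beyond the scatter) and a 23-fold lower number from compound 2 to compound 3 (1.36 log units; beyond the scatter).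

Going by the values given here, no compound with a 4-hydroxyphenyl group has been measured, but its single hydroxy group suggests a place between compound 3 and compound 2. A clear move towards weaker inhibition is expected, with an estimated 4.5-fold higher number from compound 3 to compound 4 (0.66 log units; beyond the scatter). Compound 4 is estimated at 4000 nM in this assay, with an expected range of 1000 nM to 16000 nM.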

Compound 4, half-maximal inhibitory concentration: 1500 nM
For compound 4 the middle estimate is 2.7-fold (0.43 log units) above the measured one; the measured number falls inside the stated range.
By their numbers in this assay, from the lowest: compound 1; then compounds 3 and 4 (each within the scatter of the next); then compound 2.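

In this assay, 4-hydroxyphenyl in place of 2,3-dihydroxyphenyl gives a 1.7-fold higher number from compound 3 to compound 4 (0.23 log units; within the scatter) and so does not separate these two groups on the saturated chain carbon. The exchange of chloro for hydroxy on an aromatic carbon gives a 13-fold lower number from compound 2 to compound 4 (1.12 log units; beyond the scatter) and shows that this single change recovers much of the large gap between the 4-chlorophenyl compound and the hydroxylated compounds. Not every hydroxylated ring behaves alike, though: 2,6-dihydroxyphenyl remains apart with a 6.0-fold higher number from compound 1 to compound 4 (0.78 log units; beyond the scatter) and gives the lowest number of the four compounds.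

Still open, going by these compounds, is whether a hydroxy group is specifically required, which an amine or a carboxylic acid on the same ring, or a longer chain leading to it, could help to test. Nothing available here explains why the hydroxy group makes this difference.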